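The compounds below may be only part of what the source reports. "The series", "measured", "known", "first", "only" and "open" are said of these compounds alone.

The series shares the structure shown by compound 1 `O=C(CN1CCN(c2ccc(F)cc2)CC1)Nc1nc2c(s1)CCC2`, compound 2 `O=C(CN1CCN(c2ccc(F)cn2)CC1)Nc1nc2c(s1)CCCC2` and compound 3 `O=C(CN1CCN(c2cccnc2)CC1)Nc1nc2c(s1)CCCC2`, all tested in an assay on isolated protein for inhibition of long-chain fatty acid transport protein 1 (Mus musculus), read by scintillation counting, with a stated time of 20 min; on this read-out higher numbers stand for weaker inhibition and lower numbers for stronger inhibition. Compound 1 gives only a limit of the assay, > 10000 nM, and no number. Going by the values given here, compound 2 gives 600 nM, the single number among the two values obtained so far. The other value is the limit at which compound 1 sits (the limit of > 10000 nM in this assay, at which 1 of the 2 values shown sits). Since compound 1 and compound 2 differ in two places, the two values are reported side by side without further comparison.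

Compound 3 has not yet been measured. It differs from compound 2 by one change: pyridin-3-yl in place of 5-fluoropyridin-2-yl on an amine nitrogen in a ring. Among the compounds with values here, no step between measured compounds is available, so the expectation for compound 3 rests on the value of compound 2 alone. Compound 3 is expected to come out somewhat weaker than compound 2, with the estimated step of a 2.5-fold higher number from compound 2 to compound 3 (0.40 log units; beyond the scatter), though a result within the scatter would not surprise. For compound 3 the estimated value in this assay is 1500 nM, expected to lie between 400 nM and 6000 nM.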

Compound 3, half-maximal inhibitory concentration: > 10000 nM
Compound 3 gave a limit, no number (the forecaster's own chance of this, stated with the estimate: 15%); middle value at least 6.6-fold (0.82 log units) away from the limit.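

The place on the amine nitrogen in a ring proves sensitive to this change, which was not visible before, since compound 1 and compound 2 differ in two places: an at least 16-fold higher number from compound 2 to compound 3 (1.22 log units; beyond the scatter). Pyridin-3-yl and 5-fluoropyridin-2-yl are both six-membered aromatic rings with 1 hetero atom and the same counts of hydrogen-bond donors and acceptors, and the entering group is smaller by a single heavy atom, so counts of this kind do not predict the outcome at this place. The value of compound 3 is a limit of the assay and not a number, so the step gives only the smallest possible size of the change and its full size cannot be read: the limit of > 10000 nM in this assay, at which 2 of the 3 values shown sit.

The change removes the fluorine and also alters the point at which the pyridine ring is attached, and the compounds shown do not separate these two differences. Plain pyridin-2-yl, or a pyridin-3-yl ring carrying a fluorine, would be needed to tell which difference accounts for the step, and it remains open whether either would stay close to compound 2.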